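The compounds below may be only part of what the source reports. "The series", "measured", "known", "first", "only" and "open" are said of these compounds alone.

Compound 1 `CC(C)c1ccccc1OS(=O)(=O)c1cccc(NC(=O)CCl)c1` and compound 2 `CC(C)c1ccccc1OS(=O)(=O)c1cccc(NC(=O)CCCl)c1` share one core; compound 3 `CC(C)c1ccccc1OS(=O)(=O)c1ccc(NC(=O)CCCl)cc1` and compound 4 `CC(C)c1ccccc1OS(=O)(=O)c1ccc(NC(=O)CCCCl)cc1` share another, and the difference between the two cores is not broken down here. In a functional assay on HT-29 cells (Homo sapiens) for antiproliferative activity, read by sulforhodamine B assay, with a stated time of 48 h (on this read-out higher numbers stand for weaker inhibition and lower numbers for stronger inhibition), compound 1 gives 4500 nM and compound 2 gives 11000 nM, so the change chloromethyl in place of chloro on a saturated chain carbon bound to a carbonyl carbon made a step of a 2.4-fold higher number from compound 1 to compound 2 (0.39 log units; beyond the scatter). Compound 3 gives 16000 nM in this assay. Compound 4 carries the same kind of change, (chloromethyl in place of chloro on a saturated chain carbon, two bonds along the chain from a carbonyl carbon), though here it sits on a saturated chain carbon, two bonds along the chain from a carbonyl carbon, rather than on a saturated chain carbon bound to a carbonyl carbon. Because the step of a 2.4-fold higher number from compound 1 to compound 2 (0.39 log units; beyond the scatter) went toward a higher number, compound 4 is expected to move the same way, by roughly a 1.6-fold higher number from compound 3 to compound 4 (0.19 log units; within the scatter). Compound 4 is estimated at 25000 nM, within 10000 nM to 60000 nM.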

Compound 4, half-maximal inhibitory concentration: 6200 nM
Beside the measured number, compound 4's estimate is 4.0-fold (0.61 log units) above it; the whole stated range lies above it.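

The change of chloro to chloromethyl gave a 2.6-fold lower number from compound 3 to compound 4 (0.41 log units; beyond the scatter) in this assay, so its direction did not carry over from one core to the other: the same change on two cores in this assay, a 2.4-fold higher number (0.39 log units; beyond the scatter) from compound 1 to compound 2 and a 2.6-fold lower number (0.41 log units; beyond the scatter) from compound 3 to compound 4, 6.3-fold (0.80 log units) apart, beyond the scatter of two such steps In this series, then, the step on the core of compound 1 did not foretell the step on the core of compound 3. This does not show that the core alone sets the direction, since each core offers a single pair and the second step sits on a saturated chain carbon, two bonds along the chain from a carbonyl carbon, so core and place remain tied together.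

The compounds shown leave open how the chain of compound 1 would behave on the core of compound 3, a comparison that would separate core from place. They also leave open how a longer chain, or an amine in place of the chlorine, would behave on either core.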